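Hydrazone aryl exchange on the shared triazole-thioacetohydrazide core

The source may hold more compounds than are shown below. What is called first, only, known or untested is meant among the compounds shown, and "the series" means these compounds.

Measured so far:
compound 1 `COc1ccc(/C=N/NC(=O)CSc2nnc(-c3ccncc3)n2-c2ccccc2)cc1`: 23700 nM
compound 2 `O=C(CSc1nnc(-c2ccncc2)n1-c1ccccc1)N/N=C/c1ccc(Br)cc1`: 7040 nM

Going by the values given here, in a functional assay on MCF7 cells (Homo sapiens) for inhibition, read by MTT assay, with a stated time of 48 h (on this read-out lower numbers stand for stronger inhibition and higher numbers for weaker inhibition), compound 2 holds the lowest of the two numbers; its nearest neighbour is compound 1, and the only step recorded between them is a 3.4-fold lower number from compound 1 to compound 2 (0.53 log units; beyond the scatter), a bromo in place of methoxy on an aromatic carbon.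

Compound 3 `O=C(CSc1nnc(-c2ccncc2)n1-c1ccccc1)N/N=C/c1cccc(F)c1` differs from compound 2 by 3-fluorophenyl in place of 4-bromophenyl on a carbon with a double bond to nitrogen. Among the compounds with values here, no measured step bears directly on this change: the single step known concerns a methoxy-to-bromo exchange, whereas here a bromine gives way to a fluorine and the substituent moves to a different ring carbon. The two aryl groups seen so far span only a modest range, so a step of comparable or smaller size is the most that can be expected, with no firm direction; a drift back toward the number of compound 1 seems somewhat more likely than a further gain.

Compound 3 is therefore estimated at 12000 nM, with a range of 4000 nM to 35000 nM. That estimate corresponds to an expected step of a 1.7-fold higher number from compound 2 to compound 3 (0.23 log units; within the scatter), which may well sit within the scatter.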

Compound 3, half-maximal inhibitory concentration: > 50000 nM
Compound 3: no number, only a limit; the forecaster's own chance of this, stated with the estimate: 5%; middle value at least 4.1-fold (0.61 log units) away from the limit.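

In this assay compound 3 has no number, only a limit: the limit of > 50000 nM in this assay, at which 1 of the 3 values shown sits.

The aryl group on the carbon with a double bond to nitrogen can therefore do more than the earlier pair showed, as 3-fluorophenyl in place of 4-bromophenyl gives an at least 7.1-fold higher number from compound 2 to compound 3 (0.85 log units; beyond the scatter). 3-fluorophenyl in place of 4-methoxyphenyl points the same way, with an at least 2.1-fold higher number from compound 1 to compound 3 (0.32 log units; beyond the scatter), so a halogen on the aryl ring does not by itself carry the gain seen with compound 2: compound 2 and compound 3 each hold one, yet they fall on opposite sides of compound 1.

From the compounds shown here alone, whether the loss goes with the fluorine or with the place of the substituent stays open, as the exchange from 4-bromophenyl to 3-fluorophenyl changes both at once. Also open, going by these compounds, are how far compound 3 lies past its limit and how an amine or a carboxylic acid on this aryl ring would read out on the shared core.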